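Replacing a hydroxyl hydrogen with methyl in a curcumin-like chain

This account rests on a few compounds, and the source may have more. Where it says the series, first, only, none or still open, it means among the compounds named here.

Of the compounds shown here, three have been measured in a functional assay, read by spectrophotometry, with a stated time of 30 min; a lower number here means that less compound is needed, a higher number that more compound is needed for the effect. Compound 2 `COc1cc(/C=C/C(=O)/C=C(/C=C/c2ccc(O)c(OC)c2)NCCO)ccc1O` gives 28300 nM in this assay. For the measured compounds named here, no measured compound gives a smaller number than compound 2, but compound 1 `COc1cc(/C=C/C2=CC(=O)CC(c3ccc(O)c(OC)c3)N2CCCO)ccc1O`, with 33900 nM in this assay, lies within the usual scatter of compound 2, so the two cannot be told apart. Compound 3 `COCCCNC(=C\C(=O)/C=C/c1ccc(O)cc1)/C=C/c1ccc(O)cc1`, which gives 130000 nM in this assay, needs clearly more compound than either, a gap beyond the scatter. Compound 3 differs from compound 2 in more than one place, so its weaker result cannot be traced to any single group.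

The new compound 4 `COCCNC(=C\C(=O)/C=C/c1ccc(O)c(OC)c1)/C=C/c1ccc(O)c(OC)c1` is compound 2 with one change: methyl in place of hydrogen on an oxygen on a saturated carbon. The remaining parts of the molecule, the chain and the two ring systems, are kept as in compound 2.

Going by the values given here, no measured pair shows this exact change on its own, so there is no direct guide. A single added methyl on a chain-end oxygen is a small change, and a step from compound 2 to compound 4 within the scatter, in either direction, is the expected outcome, with a slight lean toward needing a little more compound. Compound 4 is therefore expected to give about 36000 nM in this assay, within a range of 12000 nM to 110000 nM, which means an expected step of a 1.3-fold higher number from compound 2 to compound 4 (0.10 log units; within the scatter).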

Compound 4, half-maximal effective concentration in the functional assay: 27300 nM
Compound 4: the middle estimate sits 1.3-fold (0.12 log units) above what was measured; measured number inside the range.
By their numbers in the functional assay, from the lowest: compounds 4, 2 and 1 (each within the scatter of the next); then compound 3.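

In the functional assay, turning the 2-hydroxyethyl group into 2-methoxyethyl gives a 1.0-fold lower number from compound 2 to compound 4 (0.02 log units; within the scatter), so this chain end accepts methyl in place of hydrogen on its oxygen, and the hydrogen on that oxygen is not needed to keep the result at this level. In a physicochemical assay for solubility, using the shake flask method, in phosphate buffer, with a stated time of 24 h, at pH 6.8 (on this read-out higher numbers stand for higher solubility and lower numbers for lower solubility), compound 2 gives 11800 nM and compound 4 gives 12700 nM, which is a 1.1-fold higher number from compound 2 to compound 4 (0.03 log units; within the scatter), so this second read-out does not separate the two compounds either. No measurement at hand explains why the change leaves both read-outs where they are.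

From the compounds shown here alone, a single methyl is a small probe, so it remains open whether the oxygen can be replaced altogether, or whether an amine, a carboxylic acid or a longer chain at this end would move the result in the functional assay. Going by these compounds, compound 1 and compound 3 differ from compound 2 in more than one place, so they say nothing about this chain end on its own, and whether the same methyl would be accepted on their cores is unknown.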